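The source may report more compounds than this note shows. Statements on the series, on what has been measured and on what is new or still open speak of the compounds shown alone.

Series notes. Compound 1 `COc1ccc(N)c(C2=NN(C(=O)CCc3ccccc3)CC2)c1` is the reference; in an assay on isolated protein for inhibition of Nitric oxide synthase, inducible (Homo sapiens), with a stated time of 30 min, tested at 1 mM (a lower number here means less inhibition, a higher number more inhibition at the concentration tested (going by the name of the read-out)), compound 1 gives 21.2%. Compound 3 `COc1cc(N)c(C2=NN(C(=O)CCc3ccccc3)CC2)cc1OC` differs from it by methoxy in place of hydrogen on an aromatic carbon, and the step is a number 2.5 percentage points higher from compound 1 to compound 3 (within the scatter). Compound 2 `COc1cc(N)c(C2=NN(C(=O)C3CC3)CC2)cc1OC` carries cyclopropyl on the carbonyl carbon where compound 3 carries phenethyl; in this assay compound 2 gives 25.2% and compound 3 gives 23.7%, the step being a number 1.5 percentage points lower from compound 2 to compound 3 (within the scatter). The difference between the core of compound 1 and the core of compound 2 is not broken down here. Compound 4 `COc1cc(N)c(C2=NN(C(=O)C3CC3)CC2)c(OC)c1OC`, still to be measured, differs from compound 2 by methoxy in place of hydrogen on an aromatic carbon. This is the same kind of change as from compound 1 to compound 3, but the surroundings differ: in compound 4 the entering group sits ortho to a large group, ortho to a methoxy group and meta to a methoxy group, whereas in compound 3 it sits ortho to a methoxy group and para to a large group. Because the earlier step of a number 2.5 percentage points higher from compound 1 to compound 3 (within the scatter) stayed small, a step of similar size is expected here, a number 1.8 percentage points higher from compound 2 to compound 4 (within the scatter). Compound 4 is therefore estimated at 27%, with an expected range from 15% to 38%.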

Compound 4, a percentage reported as inhibition, at one concentration (the size of the read-out at that concentration, not a potency): 30.1%
The estimate for compound 4 lay 3.1 percentage points below the measured number; the range from low to high includes it.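

In this assay, methoxy in place of hydrogen on an aromatic carbon gives a number 4.9 percentage points higher from compound 2 to compound 4 (within the scatter). Set beside the earlier case of the same change on another core, the two steps cannot be told apart: the same change on two cores in this assay, a number 2.5 percentage points higher (within the scatter) from compound 1 to compound 3 and a number 4.9 percentage points higher (within the scatter) from compound 2 to compound 4, 2.4 percentage points apart, within the scatter of two such steps. This shows that the change carries between these two cores without a step that stands out from the scatter, but it does not show that methoxy at either place truly shifts inhibition, and the entering group has different surroundings in the two cases, so the core and the position of the change are not separated.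

The compounds shown leave open how other groups at this aromatic carbon would read, such as hydroxyl, fluorine or ethoxy, and how groups other than cyclopropyl and phenethyl on the carbonyl carbon would read, such as an amine-bearing chain or a carboxylic acid. All readings are at one concentration and give no potency.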